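Hydroxymethyl in place of phenoxy: expected Vero cell cytotoxicity

The compounds below may be only part of what the source reports. "The series", "measured", "known", "first", "only" and "open" are said of these compounds alone.

Three compounds have been examined in an ADME assay on Vero cells (Chlorocebus sabaeus) for cytotoxicity, read by MTT assay, with a stated time of 48 h; a lower number here means a stronger inhibitor, a higher number a weaker inhibitor. Compound 1 `O=C(NN=C1CCC(c2ccccc2)CC1)c1ccncc1` gives > 200000 nM, which is a limit of this assay rather than a number. Compound 3 `NNC(=O)c1ccnc(NN)c1` gives > 200000 nM, again a limit. Compound 2 `O=C(N/N=C/c1ccc(Oc2ccccc2)cc1)c1ccncc1` has "not determined" (no result reported) in this assay, so no number places it. What the data show instead is the limit of > 200000 nM in this assay, at which 2 of the 3 values shown sit. Compound 4 `O=C(N/N=C/c1ccc(CO)cc1)c1ccncc1` differs from compound 2 in one place: hydroxymethyl in place of phenoxy on an aromatic carbon. Within the data shown here, no step between measured compounds is available in this assay, so the size of the step from compound 2 to compound 4 cannot be read from a measured pair; the author expects no shift beyond the usual scatter. Compound 4 is therefore expected to give about 200000 nM in this assay, between 100000 nM and 500000 nM, most likely reported as a limit.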

Compound 4, half-maximal inhibitory concentration in the Vero assay: > 200000 nM
Compound 4 was reported as a limit (the forecaster's own chance of this, stated with the estimate: 80%); the middle value sits exactly at the limit.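

Among these compounds, no step from compound 2 to compound 4 can be read in the Vero assay. In a physicochemical assay for lipophilicity, using the shake flask method, measured as octanol-water partition (a lower number here means a more polar compound, a higher number a more lipophilic compound), compound 2 gives 3.7 and compound 4 gives 0.731. The compounds shown leave open whether hydroxymethyl in place of phenoxy shifts the read-out of the Vero assay at all.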